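From acetamido to ureido on a shared core

The source may hold more compounds than are shown below. What is called first, only, known or untested is meant among the compounds shown, and "the series" means these compounds.

Compound 1 `Cc1cnc(N)nc1-c1ccccc1`: 34%
Compound 2 `CC(=O)Nc1nccc(-c2ccncc2)n1`: 52%

In a functional assay on the whole organism for inhibition, with Rattus norvegicus as the target, with stated times of 1 h and 3.5 h, at a dose of 100 mg/kg by the oral route (a higher number here means more inhibition at the dose given (going by the name of the read-out), a lower number less inhibition), compound 1 gives 34%. Compound 2 gives 52%, the highest of the two numbers shown, standing beyond the scatter above compound 1. Compound 3 `NC(=O)Nc1nccc(-c2ccncc2)n1` is not yet measured. It differs from compound 2 in one place: amino in place of methyl on a carbonyl carbon, which cut one bond further out reads acetamido to ureido. Among the compounds with values here, no measured pair shows this change, so compound 3 is expected to stay close to compound 2, with a step of a number 4 percentage points lower from compound 2 to compound 3 (within the scatter), within the scatter in either direction. Compound 3 is therefore estimated at 48%, between 28% and 68%.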

Compound 3, a percentage reported as inhibition, in the whole organism at one dose (the size of the read-out at that dose, not a potency): 12%
Estimate against measurement, compound 3: 36 percentage points above; measured number below the stated range.
By their numbers in this assay, from the lowest: compound 3; then compound 1; then compound 2.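

In this assay, amino in place of methyl on a carbonyl carbon, which reads acetamido to ureido, gives a number 40 percentage points lower from compound 2 to compound 3 (beyond the scatter). Within the data shown here, this is the first pair differing in one place, and it shows that the read-out at this dose depends strongly on what sits on this carbonyl carbon, even when one heavy atom is exchanged for another. Nothing available accounts for the drop. From the compounds shown here alone, it remains open whether an ethyl group or a methylamino group on the same carbonyl carbon would stay near compound 2 or fall towards compound 3. Going by these compounds, the shared core with other groups on this carbonyl carbon also remains unexplored here.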